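A few compounds are considered here, and "the series" means these few. Any claim that something is new, unique, unknown or untested is made for them only; others in the source may bear on it.

Compound 1 `CCc1cccc2c(OC)c(-c3occ(C)c3C(=O)OC)ccc12`, compound 2 `CCOC(=O)c1c(C)coc1-c1ccc2c(CC)cccc2c1OC` and compound 3 `CCc1cccc2c(OC)c(-c3occ(C)c3COC)ccc12` share one core and were tested in a functional assay on DU-145 cells (Homo sapiens) for cytotoxicity, read by MTT assay, with a stated time of 72 h; on this read-out lower numbers stand for an effect already at smaller amounts and higher numbers for an effect only at larger amounts of compound. In this assay compound 1 gives 2.2 ug/mL. Compound 2 gives 2.2 ug/mL in this assay. For compound 3 this assay reports only a limit and not a number, > 10 ug/mL, which is the limit of > 10 ug/mL in this assay, at which 1 of the 3 values shown sits.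

Compound 2 differs from compound 1 by methyl in place of hydrogen on a saturated chain carbon bound to an oxygen next to a carbonyl group, and the step is no change at the digits printed from compound 1 to compound 2 (within the scatter). Compound 3 differs from compound 1 by methoxymethyl in place of methoxycarbonyl on an aromatic carbon; the step is an at least 4.5-fold higher number from compound 1 to compound 3 (0.65 log units; beyond the scatter). Compound 3 against compound 2 shows a methoxymethyl where compound 2 carries an ethoxycarbonyl, and the step is an at least 4.5-fold higher number from compound 2 to compound 3 (0.65 log units; beyond the scatter).

Compound 4 `CCOCc1c(C)coc1-c1ccc2c(CC)cccc2c1OC` has not yet been measured in this assay. It differs from compound 3 by methyl in place of hydrogen on a saturated chain carbon bound to an oxygen on a saturated carbon. This is the same kind of change as that from compound 1 to compound 2, but not the same: there the carbon sat on an oxygen next to a carbonyl group, here it sits on an oxygen on a saturated carbon, and the two cores differ in the way already described for compound 3 against compound 1. The step expected for compound 4 is a step that the limit leaves unreadable from compound 3 to compound 4, and it rests on the earlier step of no change at the digits printed from compound 1 to compound 2 (within the scatter). Compound 4 is therefore estimated at 20 ug/mL in this assay, with a range from 8 ug/mL to 60 ug/mL, most likely again reported only as a limit.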

Compound 4, concentration for half-maximal effect: > 10 ug/mL
Compound 4: no number, only a limit (the forecaster's own chance of this, stated with the estimate: 80%); the middle value is on the limit's open side.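

Compound 4, with ethoxymethyl, stands apart in this assay from both compounds that carry a carbonyl group (an at least 4.5-fold higher number from compound 2 to compound 4 (0.65 log units; beyond the scatter)) and (an at least 4.5-fold higher number from compound 1 to compound 4 (0.65 log units; beyond the scatter)), so among the four compounds shown, the two with a carbonyl group on the aromatic carbon give numbers and the two with an ether chain there give limits, and no compound goes against this. On the core of compound 1, methyl in place of hydrogen gave (no change at the digits printed from compound 1 to compound 2 (within the scatter)), but the compounds shown neither confirm nor refute that this result carries over to the core of compound 3. Compound 4 gives only a limit and not a number (> 10 ug/mL), and the step to it from compound 3 cannot be read, since both compounds stand at a limit: the limit of > 10 ug/mL in this assay, at which 2 of the 4 values shown sit.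

As far as these compounds go, the real numbers of compound 3 and compound 4 stay open, so any difference between methoxymethyl and ethoxymethyl may lie hidden beyond the limit. From the compounds shown here alone, it also stays open how a carboxylic acid, an amine or a longer chain such as propoxymethyl in that place on the aromatic carbon would read in this assay, and whether any of them would give a number rather than a limit.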